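Bromo to methyl at the phenyl end of the series

The compounds below may be only part of what the source reports. "The series", "measured", "known", "first", "only" and "open" are said of these compounds alone.

Measured so far in a functional assay on PC-3 cells (Homo sapiens) for cytotoxicity, read by sulforhodamine B assay, with a stated time of 48 h; on this read-out higher numbers stand for weaker inhibition and lower numbers for stronger inhibition:
compound 1 `CC1=C(/C=C/C(=O)/C=C/c2ccccc2)C(C)(C)CCC1`: 12400 nM
compound 2 `CC1=C(/C=C/C(=O)/C=C/c2ccccc2Cl)C(C)(C)CCC1`: 11300 nM
compound 3 `CC1=C(/C=C/C(=O)/C=C/c2ccccc2Br)C(C)(C)CCC1`: 11400 nM

On the numbers shown, compound 3 gives the second highest value of the three in this assay. Its closest neighbour is compound 2, with a 1.0-fold higher number from compound 2 to compound 3 (0.00 log units; within the scatter), and its furthest is compound 1, with a 1.1-fold lower number from compound 1 to compound 3 (0.04 log units; within the scatter); all three compounds sit within the scatter of one another, so no ordering among them can be read.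

Compound 4 `CC1=C(/C=C/C(=O)/C=C/c2ccccc2C)C(C)(C)CCC1` differs from compound 3 by methyl in place of bromo on an aromatic carbon. Among the measured compounds shown here, no methyl-bearing analogue has been measured, so the step rests on indirect evidence: the substitutions made so far at this position, a 1.1-fold lower number from compound 1 to compound 2 (0.04 log units; within the scatter) and a 1.1-fold lower number from compound 1 to compound 3 (0.04 log units; within the scatter), and the swap a 1.0-fold higher number from compound 2 to compound 3 (0.00 log units; within the scatter), all stayed within the scatter. The position has so far tolerated hydrogen, chloro and bromo without a change beyond the scatter, which suggests that methyl will behave the same way.

Accordingly a 1.0-fold higher number from compound 3 to compound 4 (0.00 log units; within the scatter) is expected, that is, no step beyond the scatter. Compound 4 is estimated at 11500 nM, with a range from 5500 nM to 24000 nM.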

Compound 4, half-maximal inhibitory concentration: 44100 nM
The estimate for compound 4 lay 3.8-fold (0.58 log units) below the measured number, outside the stated range (above it).
By their numbers in this assay, from the lowest: compounds 2, 3 and 1 (each within the scatter of the next); then compound 4.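

In this assay, among the compounds shown here, this position is not indifferent to every group: methyl brings the first steps beyond the scatter, with a 3.9-fold higher number from compound 3 to compound 4 (0.59 log units; beyond the scatter), a 3.9-fold higher number from compound 2 to compound 4 (0.59 log units; beyond the scatter) and a 3.6-fold higher number from compound 1 to compound 4 (0.55 log units; beyond the scatter), while hydrogen, chloro and bromo remain within the scatter of one another. The swap from bromo to methyl leaves the heavy-atom, hydrogen-bond donor and hydrogen-bond acceptor counts as they were, so these counts do not separate compound 3 from compound 4. Nothing available here accounts for the higher number with methyl.

Open, as far as these compounds go, is whether this higher number belongs to methyl alone or extends to a longer chain such as ethyl. Also open, from the compounds shown here alone, is where methoxy, an amine or a carboxylic acid would fall at this position relative to compound 1 and compound 4.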